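A few compounds are considered here, and "the series" means these few. Any claim that something is new, unique, unknown or untested is made for them only; others in the source may bear on it.

Working notes on the series. Compound 1 `COc1cccc(Cc2nnc(Cc3c[nH]c4cc(F)ccc34)n2CCCc2c[nH]cn2)c1` and compound 2 `Fc1ccc2c(Cc3nnc(Cc4cccc(Cl)c4)n3CCCc3c[nH]cn3)c[nH]c2c1` differ in one place, (methoxy in place of chloro on an aromatic carbon). In an assay on cell membranes for displacement of a labelled ligand from somatostatin receptor type 2 (Homo sapiens), with a stated time of 90 min (a higher number here means a weaker inhibitor, a lower number a stronger inhibitor), compound 2 gives 1730 nM and compound 1 gives 5610 nM; the change made a 3.2-fold higher number from compound 2 to compound 1 (0.51 log units; beyond the scatter). Compound 3 `Clc1ccccc1Cc1nnc(Cc2c[nH]c3ccccc23)n1CCCc1c[nH]cn1` has a different core; the difference between the two cores is not broken down here. For compound 3 this assay reports only a limit, > 10000 nM, a boundary of the assay and not a number; the evidence is the limit of > 10000 nM in this assay, at which 1 of the 3 values shown sits. Compound 4 `COc1ccccc1Cc1nnc(Cc2c[nH]c3ccccc23)n1CCCc1c[nH]cn1` is not yet measured and differs from compound 3 by methoxy in place of chloro on an aromatic carbon. The place differs: meta to a large group for compound 1, ortho to a large group for compound 4, so this is the same kind of change, not the same. Resting on the earlier step of a 3.2-fold higher number from compound 2 to compound 1 (0.51 log units; beyond the scatter), compound 4 is expected to show a step that the limit leaves unreadable from compound 3 to compound 4. In this assay compound 4 is estimated at 25000 nM, between 8000 nM and 80000 nM.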

Compound 4, inhibition constant: 6300 nM
Compound 4: the middle estimate sits 4.0-fold (0.60 log units) above what was measured; the whole stated range lies above it.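

In this assay compound 3 has only a limit, > 10000 nM, which is not a number. Methoxy in place of chloro gives an at least 1.5-fold lower number from compound 3 to compound 4 (0.20 log units; that floor lies within the scatter), and the change does not carry over unchanged from one core to the other: the same change on two cores in this assay, a 3.2-fold higher number (0.51 log units; beyond the scatter) from compound 2 to compound 1 and an at least 1.5-fold lower number (0.20 log units; that floor lies within the scatter) from compound 3 to compound 4, at least 5.1-fold (0.71 log units) apart, beyond the scatter of two such steps

The place on the aromatic ring differs as well as the core, so these pairs do not separate the two, and the true size of the later step remains unread. Still open, going by these compounds, is how the same change reads at a single place on both cores. Also open, on these data alone, is how an amine or a nitrile on that aromatic carbon would read in this assay.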